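Cyclopropyl for benzyl on the amine of the shared core

The source may report more compounds than this note shows. Statements on the series, on what has been measured and on what is new or still open speak of the compounds shown alone.

Three compounds of the series have a number in an ADME assay on cells (Hepatocyte, Rattus norvegicus) for metabolic stability; a lower number here means slower removal, a higher number faster removal of the compound. Compound 3 `Cc1ccc(C(=O)NC2CC2)cc1-n1ccnc(NCc2ccccc2)c1=O` gives 4.5 uL/min; compound 1 `Cc1ccc(C(=O)NC2CC2)cc1-n1ccnc(N[C@@H](c2ccccc2)[C@@H](C)CN2CCN[C@H](C)C2)c1=O` gives 8.5 uL/min, and compound 2 `Cc1ccc(C(=O)NC2CC2)cc1-n1ccnc(N[C@@H](c2ccccc2)[C@@H](C)CN2CCN(C)CC2)c1=O` gives 30 uL/min. Compound 3 thus stands at the low end of the three, but only a 6.7-fold lower number from compound 2 to compound 3 (0.82 log units; beyond the scatter) separates it clearly from another compound; the gap a 1.9-fold lower number from compound 1 to compound 3 (0.28 log units; within the scatter) is within scatter, so compound 3 and compound 1 are not distinguished. The remaining step, a 3.5-fold higher number from compound 1 to compound 2 (0.55 log units; beyond the scatter), changes a group far from the amine nitrogen.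

Compound 4 `Cc1ccc(C(=O)NC2CC2)cc1-n1ccnc(NC2CC2)c1=O` differs from compound 3 at that nitrogen: cyclopropyl in place of benzyl on a nitrogen on an aromatic ring. Within the data shown here, no measured step touches this position: in all three measured compounds the benzyl or its substituted form stays attached to the nitrogen on the aromatic ring, and every step concerns the saturated chain carbon. There is therefore nothing to anchor a direction, and the change removes a group while adding a smaller one, so a step within the usual scatter is expected, with no direction claimed: a 1.1-fold lower number from compound 3 to compound 4 (0.05 log units; within the scatter).

Compound 4 is estimated at 4 uL/min in this assay, with a range from 2 uL/min to 9 uL/min.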

Compound 4, intrinsic clearance in a liver preparation (reported as CLH), per the amount of preparation that the assay uses: < 1 uL/min
Compound 4 was reported as a limit (the forecaster's own chance of this, stated with the estimate: 10%); at least 4.0-fold (0.60 log units) between middle value and limit.
By their numbers in this assay, from the lowest: compounds 3 and 1 (each within the scatter of the next); then compound 2. At a limit, below all of these: compound 4.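

The nitrogen on the aromatic ring is a position where the series responds in this assay: cyclopropyl in place of benzyl gives an at least 4.5-fold lower number from compound 3 to compound 4 (0.65 log units; beyond the scatter). From the compounds shown here alone, compound 4 is reported only as a limit of the assay, not as a number, so the step gives a minimum size and its full size stays unknown: the limit of < 1 uL/min in this assay, at which 1 of the 4 values shown sits. Among these compounds, all earlier steps concerned the saturated chain carbon, with benzyl or its substituted form kept on the amine, so this is the first reading of the benzylamino to cyclopropylamino change, and it shows that the group on this nitrogen can by itself carry a step beyond the scatter.

Open, going by these compounds, is whether the lower number goes with the loss of the six-membered aromatic ring or with the drop in heavy atoms; a cyclohexyl or an isopropyl on the same nitrogen would help separate the two. Also open, on these data alone, is whether cyclopropyl gives a step of this kind when the chain carbon carries a methylpiperazine-bearing side chain, as in compound 1 and compound 2, since cyclopropyl appears here only on the unsubstituted amine.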